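From benzyl to 3,4-dichlorobenzyl at an assay limit

The compounds below may be only part of what the source reports. "The series", "measured", "known", "first", "only" and "open" are said of these compounds alone.

In a physicochemical assay for solubility, with a stated time of 3 days, at pH 2 (on this read-out lower numbers stand for lower solubility and higher numbers for higher solubility), compound 1 `NC(=O)c1ccc2[nH]c(-c3ccc(OC4CCCNC4)cc3)nc2c1` gives > 400000 nM, which is a limit and not a number. For compound 2 `COc1ccc(CN2CCCC(COc3ccc(-c4nc5cc(C(N)=O)ccc5[nH]4)cc3)C2)cc1` the entry reads "not determined" (no result reported). Compound 3 `NC(=O)c1ccc2[nH]c(-c3ccc(OCCC4CCCCN4Cc4ccccc4)cc3)nc2c1` gives > 400000 nM, again a limit. Compound 3 therefore stands at the limit of > 400000 nM in this assay, at which 2 of the 3 values shown sit, with no exact number of its own. Compound 4 `NC(=O)c1ccc2[nH]c(-c3ccc(OCCC4CCCCN4Cc4ccc(Cl)c(Cl)c4)cc3)nc2c1` carries 3,4-dichlorophenyl in place of phenyl on a saturated chain carbon bound to an amine nitrogen in a ring. Going by the values given here, no measured step in this assay gauges this change, so only a modest move towards lower numbers is expected, possibly none beyond the scatter. The estimated step is an at least 1.3-fold lower number from compound 3 to compound 4 (0.12 log units; that floor lies within the scatter). For compound 4 the expected value is 300000 nM, with an estimated range of 80000 nM to 500000 nM.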

Compound 4, solubility: 39000 nM
Beside the measured number, compound 4's estimate is 7.7-fold (0.89 log units) above it, outside the stated range (below it).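

Going by these compounds alone, replacing phenyl with 3,4-dichlorophenyl on a saturated chain carbon bound to an amine nitrogen in a ring gives the first readable step at this position in this assay, an at least 10-fold lower number from compound 3 to compound 4 (1.01 log units; beyond the scatter). Compound 4 is the only compound shown with an exact number. The step is only a floor, since compound 3 carries a limit and not a number: the limit of > 400000 nM in this assay, at which 2 of the 4 values shown sit. The compounds shown leave open how far the step really reaches. They also leave open whether a single chlorine or a trifluoromethyl group on this ring would move the number as well.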